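From compound 1 to compound 3: a large group for fluoro

The compounds below may be only part of what the source reports. "The series", "measured", "known", "first", "only" and "open" are said of these compounds alone.

Measured compounds:
Compound 1 `COc1ccnc(-c2cnc(C(=O)CCCCCCc3ccccc3)o2)c1`: 0.8 nM
Compound 2 `O=C(CCCCCCc1ccccc1)c1ncc(-c2cc(C(F)(F)F)ccn2)o1`: 3.5 nM

Both compounds were tested in an assay (Rattus norvegicus) for inhibition of Fatty-acid amide hydrolase 1 (Homo sapiens); on this read-out lower numbers stand for stronger inhibition and higher numbers for weaker inhibition. Compound 1 gives the lowest of the two numbers, and compound 2 is nearest to it with a higher number. Among the compounds with values here, the only measured step is a 4.4-fold higher number from compound 1 to compound 2 (0.64 log units; beyond the scatter), where the change sits on the outer ring while the rest of the molecule is kept.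

Compound 3 `O=C(CCCCCCc1ccccc1)c1ncc(F)o1` has not yet been tested in this assay. It differs from compound 1 in one place: fluoro in place of 4-methoxypyridin-2-yl on an aromatic carbon. The measured step touches only the substituent on the 4-methoxypyridin-2-yl group, so it does not show what happens when that whole group is removed and a single fluorine is put on the shared core in its place. With the large group gone, a considerably higher number, meaning weaker inhibition, is expected, estimated as a 500-fold higher number from compound 1 to compound 3 (2.70 log units; beyond the scatter). For compound 3 the estimate in this assay is 400 nM, with a range from 40 nM to 4000 nM.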

Compound 3, inhibition constant: 30 nM
The estimate for compound 3 lay 13-fold (1.12 log units) above the measured number, outside the stated range (below it).
By their numbers in this assay, from the lowest: compound 1; then compound 2; then compound 3.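

In this assay, trading the whole 4-methoxypyridin-2-yl group for a single fluoro gives a 38-fold higher number from compound 1 to compound 3 (1.57 log units; beyond the scatter), a clearly larger change than the outer-ring edit seen earlier, a 4.4-fold higher number from compound 1 to compound 2 (0.64 log units; beyond the scatter). So this position on the shared core matters more when the entire aromatic ring is removed than when only the substituent on that ring is exchanged. Even so, compound 3 still gives 30 nM with no ring at this place, which shows that inhibition in this assay does not depend on having the ring there, although compound 1 with the ring gives the lower number; no supporting data are available to explain this difference.

The compounds shown leave open how much of the step belongs to the ring itself and how much to its methoxy group, a question that a plain pyridin-2-yl at the same carbon would help to answer. They also leave open whether fluoro contributes anything of its own, which a comparison with hydrogen or chlorine at that carbon could settle.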